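Triazole esters: thiophen-3-yl for isopropyl on the core

A few compounds are considered here, and "the series" means these few. Any claim that something is new, unique, unknown or untested is made for them only; others in the source may bear on it.

The series shares one core, seen in compound 1 `COC(=O)c1nc(C)n(-c2cccc(Br)c2)n1`, and varies the group on the aromatic carbon and the aryl on the ring nitrogen. In a functional assay on NCI-H226 cells (Homo sapiens) for inhibition, read by MTT assay, with a stated time of 72 h (on this read-out lower numbers stand for stronger inhibition of growth and higher numbers for weaker inhibition of growth), compound 1 gives 7350 nM. Compound 2 `COC(=O)c1nc(C)n(-c2ccc(OC)cc2)n1` carries a methoxyphenyl on the ring nitrogen; in this assay compound 2 gives > 100000 nM, a limit of the assay rather than a number (the limit of > 100000 nM in this assay, at which 1 of the 3 values shown sits). Compound 3 `COC(=O)c1nc(C(C)C)n(-c2ccc(F)cc2)n1` carries an isopropyl on the aromatic carbon and a fluorophenyl on the ring nitrogen; in this assay compound 3 gives 6170 nM, the lowest of the two numbers, with compound 1 lying within the scatter of it. Compound 4 `COC(=O)c1nc(-c2ccsc2)n(-c2ccc(F)cc2)n1` is not yet measured. It differs from compound 3 by thiophen-3-yl in place of isopropyl on an aromatic carbon. For the measured compounds named here, no pair of measured compounds changes this position, so no measured step gives the size of such a change, and the two numbers known come from compounds that also differ on the ring nitrogen. With nothing to set a direction, the expected step from compound 3 to compound 4 is a 1.1-fold lower number from compound 3 to compound 4 (0.05 log units; within the scatter), which means no change beyond the scatter or a modest one either way. For compound 4 the estimate in this assay is 5500 nM, with a range from 1500 nM to 25000 nM.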

Compound 4, concentration for 50% growth inhibition: 6940 nM
Compound 4: middle estimate off by 1.3-fold (0.10 log units), on the low side, and the stated range covers the measured number.
By their numbers in this assay, from the lowest: compounds 3, 4 and 1 (each within the scatter of the next). At a limit, above all of these: compound 2.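

In this assay, the series now has its first measured step at this position, with the ring-nitrogen fluorophenyl held constant: a 1.1-fold higher number from compound 3 to compound 4 (0.05 log units; within the scatter) for thiophen-3-yl in place of isopropyl. On this background, the aromatic carbon between two ring nitrogen atoms therefore takes either group without a change beyond the scatter, although the entering group brings a five-membered aromatic ring, 5 heavy atoms against 3, a sulfur and a hydrogen-bond acceptor. Nothing measured here accounts for how closely the two groups read.

Open: whether any group at this position moves the number beyond the scatter, for example a phenyl, an amine or a longer chain, and whether methyl reads like isopropyl and thiophen-3-yl when the fluorophenyl is kept on the ring nitrogen. Also open, going by these compounds, is whether the same tolerance holds with another aryl on the ring nitrogen, such as the 3-bromophenyl of compound 1, and whether a carboxylic acid in place of the methoxycarbonyl group keeps this level of growth inhibition.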